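A Propylcarbonyl for a Phenyl on the Shared Core

The source may hold more compounds than are shown below. What is called first, only, known or untested is meant among the compounds shown, and "the series" means these compounds.

Compound 1, `c1ccc(-c2ccc(Cn3cncc3CNc3ccc(-c4ccccc4)c(-c4ccccc4)c3)cc2)cc1`: > 10000 nM
Compound 2, `COC(=O)c1ccc(NCc2cncn2Cc2ccccc2Br)cc1-c1ccccc1`: 10000 nM

In a toxicity assay on NIH3T3 cells (Mus musculus) for cytotoxicity, read by resazurin assay (a higher number here means that more compound is needed for the effect, a lower number that less compound is needed), compound 1 has only a limit, > 10000 nM, and not a number; it therefore stands at the limit of > 10000 nM in this assay, at which 1 of the 2 values shown sits. Compound 2 is the second measured member of the set, and in this assay compound 2 gives 10000 nM. Going by the values given here, no two of the measured compounds differ in a single place, so no measured step between them can be drawn, and of compound 1 and compound 2 only the two values themselves can be said.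

Compound 3, `CCCC(=O)c1ccc(NCc2cncn2Cc2ccc(-c3ccccc3)cc2)cc1-c1ccccc1`, is the compound still to be tested. It differs from compound 1 by propylcarbonyl in place of phenyl on an aromatic carbon. Since the nearest measured neighbour sits at a limit, the expectation is that a number no higher from compound 1 to compound 3 (the limit leaves the size open) amounts to nothing beyond the usual scatter. For compound 3 the estimate in this assay is 10000 nM, expected to lie between 3000 nM and 30000 nM.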

Compound 3, half-maximal effective concentration: > 10000 nM
Compound 3: no number, only a limit; the forecaster's own chance of this, stated with the estimate: 50%; the middle value lies on the limit itself.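

In this assay compound 3 gives > 10000 nM, a limit and not a number, so the step from compound 1, also held only at a limit, to compound 3 cannot be read. The compounds shown leave open whether propylcarbonyl in place of phenyl changes the value at all.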